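Swapping an acetyl for a chlorobenzoyl on the shared core

The compounds below may be only part of what the source reports. "The series", "measured", "known", "first", "only" and "open" are said of these compounds alone.

Measured compounds:
compound 1 `O=C(Nc1cc(C(F)(F)F)cc(C(F)(F)F)c1)C1CCc2ccccc2N1C(=O)c1ccccc1Cl`: 4050 nM
compound 2 `CC(=O)N1c2ccccc2CCC1C(=O)Nc1ccccc1O`: 54500 nM

Of the compounds shown here, two have been tested in a functional assay on HCT-15 cells (Homo sapiens) for cytotoxicity, read by sulforhodamine B assay, with a stated time of 72 h; on this read-out lower numbers stand for stronger inhibition of growth and higher numbers for weaker inhibition of growth. Compound 1 gives 4050 nM, whereas compound 2 gives 54500 nM, the higher of the two numbers and a gap that lies well beyond the usual scatter. Compound 3 `O=C(Nc1ccccc1O)C1CCc2ccccc2N1C(=O)c1ccccc1Cl` has not yet been measured. It differs from compound 2 in one place: 2-chlorophenyl in place of methyl on a carbonyl carbon, so that the acetyl on the ring nitrogen becomes a (2-chlorophenyl)carbonyl. Compound 1 carries this same (2-chlorophenyl)carbonyl, although it also differs from compound 3 elsewhere, so the two measured values only hint at the effect of this single change. On that basis compound 3 is expected to give a lower number than compound 2, with the step of a 4.5-fold lower number from compound 2 to compound 3 (0.66 log units; beyond the scatter) estimated to lie beyond the scatter. The estimated value for compound 3 is 12000 nM, within a range of 3500 nM to 40000 nM.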

Compound 3, concentration for 50% growth inhibition: 44900 nM
Beside the measured number, compound 3's estimate is 3.7-fold (0.57 log units) below it, outside the stated range (above it).
By their numbers in this assay, from the lowest: compound 1; then compounds 3 and 2 (each within the scatter of the next).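

In this assay, the result is a 1.2-fold lower number from compound 2 to compound 3 (0.08 log units; within the scatter): with the rest of the molecule unchanged, putting 2-chlorophenyl in place of methyl on this carbonyl carbon leaves the number within the scatter. The much lower number of compound 1, 4050 nM, therefore cannot be credited to the (2-chlorophenyl)carbonyl on its own, and compound 1 also differs from compound 3 elsewhere in the molecule. Nothing measured here explains why this change makes so little difference.

The compounds shown leave open whether an amine or a longer carbon chain in place of the methyl would move the number beyond the scatter. They also leave open whether the acetyl to (2-chlorophenyl)carbonyl change would matter more on the rest of the molecule as it stands in compound 1.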